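Trading Trifluoromethyl for Chloro in a Cytotoxicity Comparison

The source may hold more compounds than are shown below. What is called first, only, known or untested is meant among the compounds shown, and "the series" means these compounds.

In an ADME assay on Vero 76 cells (Chlorocebus sabaeus) for cytotoxicity, read by MTT assay, with a stated time of 96 h (on this read-out lower numbers stand for higher toxicity in this test and higher numbers for lower toxicity in this test), compound 1 (`FC(F)(F)c1ccc(-c2nn(-c3ccccc3)cc2CNc2ccc(Cl)cc2)cc1`) gives 10000 nM. Compound 2 (`FC(F)(F)c1ccc(NCc2cn(-c3ccccc3)nc2-c2ccccc2)cc1`) gives 17000 nM, which places it within the scatter of compound 1. Compound 3 (`Clc1ccc(NCc2cn(-c3ccccc3)nc2-c2ccccc2)cc1`), not yet measured, has chloro in place of trifluoromethyl on an aromatic carbon of compound 2 (chloro in place of trifluoromethyl on an aromatic carbon). Among the measured compounds shown here, no measured step isolates this change, but compound 1, which also carries chloro, gives 10000 nM. No change beyond the scatter is therefore expected in this assay. The estimated step of a 1.1-fold lower number from compound 2 to compound 3 (0.05 log units; within the scatter) is small. For compound 3, the expected value is 15000 nM, with an estimated range of 7000 nM to 40000 nM.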

Compound 3, half-maximal cytotoxic concentration: 65000 nM
Compound 3: middle estimate off by 4.3-fold (0.64 log units), on the low side; measured number outside the range, above it.
By their numbers in this assay, from the lowest: compounds 1 and 2 (each within the scatter of the next); then compound 3.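

In this assay, chloro and trifluoromethyl are not interchangeable on this aromatic carbon, para to a large group: the swap gives a 3.8-fold higher number from compound 2 to compound 3 (0.58 log units; beyond the scatter) and moves the number towards lower toxicity in this test. Replacing trifluoromethyl with hydrogen elsewhere in the molecule, with chloro kept, gives a 6.5-fold higher number from compound 1 to compound 3 (0.81 log units; beyond the scatter) as well, so compound 3, the only one without trifluoromethyl, stands apart from compound 1 and compound 2. Nothing available here explains these steps.

On these data alone, whether the rise follows from the arrival of chloro or the loss of trifluoromethyl stays open. So does how a methoxy group or an amine on this carbon would read.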